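This account rests on a few compounds, and the source may have more. Where it says the series, first, only, none or still open, it means among the compounds named here.

Measured so far:
- compound 1, `CNC(=O)c1ccc(-c2cnc(NCc3c(F)ccc4c3CCO4)c3cn[nH]c(=O)c23)c(C)n1`: 19000 nM
- compound 2, `CC1(C)CC(=O)N(c2cnc(NCc3c(F)ccc4c3CCO4)n3cnnc23)C1`: 57000 nM
- compound 3, `Cc1nc(C(=O)N(C)C)ccc1-c1cnc(NCc2c(F)ccc3c2CCO3)c2cn[nH]c(=O)c12`: 403000 nM

In a physicochemical assay for solubility, read by LC-MS, in phosphate buffer, with a stated time of 24 h, at pH 7.4 (on this read-out higher numbers stand for higher solubility and lower numbers for lower solubility), compound 2 stands second highest of the three, sitting between compound 1 and compound 3. For the measured compounds named here, the one single-point change measured so far, a 21-fold higher number from compound 1 to compound 3 (1.33 log units; beyond the scatter), concerns a different core and a different kind of change from the one considered here. Compound 4, `COCCC(=O)Nc1cnc(NCc2c(F)ccc3c2CCO3)n2cnnc12`, differs from compound 2 in one place: ((2-methoxyethyl)carbonyl)amino in place of 4,4-dimethyl-2-oxopyrrolidin-1-yl on an aromatic carbon. Going by the values given here, no measured step follows this kind of exchange, so the direction is uncertain, and a step within the scatter or a modest one either way is expected. The estimate for compound 4 is 50000 nM, in the range 15000 nM to 170000 nM, which would mean an expected 1.1-fold lower number from compound 2 to compound 4 (0.06 log units; within the scatter).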

Compound 4, solubility: 980000 nM
For compound 4 the middle estimate is 20-fold (1.29 log units) below the measured one, and the stated range ends below it.
By their numbers in this assay, from the lowest: compound 1; then compound 2; then compound 3; then compound 4.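

In this assay, the position on the aromatic carbon responds strongly to its group: ((2-methoxyethyl)carbonyl)amino in place of 4,4-dimethyl-2-oxopyrrolidin-1-yl gives a 17-fold higher number from compound 2 to compound 4 (1.24 log units; beyond the scatter). The entering group has no ring and adds a hydrogen-bond donor, but these differences arrive together in one exchange, so this step cannot separate them. No available measurement explains the size of the step. Still open, as far as these compounds go, is how a plain acetylamino group, lacking the methoxy end, or a primary amine would read at this position. From the compounds shown here alone, whether the same exchange would give a similar step on another core also remains open.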